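Iodo to Trifluoromethyl on a Weakly Cytotoxic Scaffold

This account rests on a few compounds, and the source may have more. Where it says the series, first, only, none or still open, it means among the compounds named here.

Three compounds sharing one core were tested in a toxicity assay on MCF-10A cells (Homo sapiens) for cytotoxicity, read by MTT assay, with a stated time of 48 h; on this read-out higher numbers stand for weaker inhibition and lower numbers for stronger inhibition. Compound 1 `O=C(/C=C/c1ccc2c(c1)B(O)OC2)c1cccnc1` gives 34400 nM. Compound 2 `Cn1cccc1C(=O)/C=C/c1ccc2c(c1)B(O)OC2` reaches only the limit of the assay, > 100000 nM. Compound 3 `O=C(/C=C/c1ccc2c(c1)B(O)OC2)c1ccc(I)cc1` likewise reaches only the limit, > 100000 nM. The steps of an at least 2.9-fold higher number from compound 1 to compound 2 (0.46 log units; beyond the scatter) and an at least 2.9-fold higher number from compound 1 to compound 3 (0.46 log units; beyond the scatter) both run toward weaker inhibition, while the step that the two limits leave unreadable from compound 2 to compound 3 cannot be read because of the limit of > 100000 nM in this assay, at which 2 of the 3 values shown sit.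

Compound 4 `O=C(/C=C/c1ccc2c(c1)B(O)OC2)c1ccc(C(F)(F)F)cc1` is not yet measured; it differs from compound 3 by trifluoromethyl in place of iodo on an aromatic carbon. Within the data shown here, no measured step touches this position, so the only guide is where compound 3 stands, at the limit. Compound 4 is therefore expected to remain near that limit, with an estimated step of a number no higher from compound 3 to compound 4 (the limit leaves the size open) that is not beyond the scatter. The estimate for compound 4 in this assay is 100000 nM, ranging from 40000 nM to 300000 nM.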

Compound 4, half-maximal inhibitory concentration: 22300 nM
For compound 4 the middle estimate is 4.5-fold (0.65 log units) above the measured one, and the stated range ends above it.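

In this assay, trifluoromethyl in place of iodo gives an at least 4.4-fold lower number from compound 3 to compound 4 (0.65 log units; beyond the scatter), a move toward stronger inhibition. Among these compounds, this shows that the group on this aromatic carbon can shift the read-out away from the limit, something the earlier compounds, with no step at this position, could not show. The true size of the step stays open because compound 3 carries only a limit: the limit of > 100000 nM in this assay, at which 2 of the 4 values shown sit.

From the compounds shown here alone, whether an amine or a carboxylic acid on the same carbon would also lower the number remains open. A single pair cannot show whether any trend holds across further groups.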